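The source may report more compounds than this note shows. Statements on the series, on what has been measured and on what is new or still open speak of the compounds shown alone.

Compound 1 `COc1ccc(-c2ccc(-c3ccc(C(=N)N)o3)o2)cc1` carries a methoxy group on the outer ring of its bis-furan amidine core. In a functional assay on HCT-116 cells (Homo sapiens) for inhibition, read by sulforhodamine B assay, with a stated time of 48 h (a lower number here means a stronger inhibitor of growth, a higher number a weaker inhibitor of growth), compound 1 gives 1070 nM. Among the measured compounds shown here, the only other compound measured here, compound 2 `N=C(N)c1ccc(-c2ccc(-c3cncc4ccccc34)s2)s1`, is built on a different core and gives 1610 nM in this assay; the two numbers lie within the scatter of each other, so neither can be set apart from the other. Compound 3 `N=C(N)c1ccc(-c2ccc(-c3ccccc3)o2)o1` has not yet been measured. It differs from compound 1 by hydrogen in place of methoxy on an aromatic carbon. For the measured compounds named here, no measured pair in this set shows what such a change does in this assay, so the expectation rests on compound 1 alone, with its value of 1070 nM. The step of a 1.4-fold higher number from compound 1 to compound 3 (0.15 log units; within the scatter) is expected to stay small, with no clear direction beyond the scatter. Compound 3 is therefore estimated at 1500 nM, most likely falling between 500 nM and 4500 nM.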

Compound 3, concentration for 50% growth inhibition: 2070 nM
Compound 3: the middle estimate sits 1.4-fold (0.14 log units) below what was measured; the measured number falls inside the stated range.
By their numbers in this assay, from the lowest: compounds 1, 2 and 3 (each within the scatter of the next).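

Among the compounds shown here, the step of a 1.9-fold higher number from compound 1 to compound 3 (0.29 log units; within the scatter) is the first measured pair in this set for hydrogen in place of methoxy, on an aromatic carbon of a six-membered aromatic ring of carbon only, para to a large group. In this assay this step does not set the two compounds apart, so the methoxy group at this place has no effect on growth inhibition that can be distinguished from the usual scatter of repeated measurements. No measurement is available that explains this result.

The compounds shown leave open whether a different group at this place, such as an amine, a hydroxyl, a chlorine or a carboxylic acid, would produce a step beyond the scatter. They also leave open whether the same exchange of methoxy for hydrogen would give a similar step on the core of compound 2.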